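This account rests on a few compounds, and the source may have more. Where it says the series, first, only, none or still open, it means among the compounds named here.

Compound 1 `Cc1cc(-c2nc3cc(F)c(F)cc3s2)ccc1N`: > 100000 nM in a functional assay on NCI-H460 cells (Homo sapiens) for inhibition (on this read-out lower numbers stand for stronger inhibition of growth and higher numbers for weaker inhibition of growth), a limit of the assay.
Compound 2 `Nc1ccc(-c2nc3cc(F)ccc3s2)cc1`: 870 nM in this assay.
Compound 3 `Nc1ccc(-c2nc3ccccc3s2)cc1F`: < 10 nM in this assay, a limit of the assay.

Compound 2 is the only one of the three with a proper number; the other two sit at the limits, one at the limit of < 10 nM in this assay, at which 1 of the 3 values shown sits, and one at the limit of > 100000 nM in this assay, at which 1 of the 3 values shown sits. For the measured compounds named here, no two measured compounds differ in a single place, so no measured step size is available. Compound 4 `Nc1ccc(-c2nc3cc(F)ccc3s2)cc1Cl` differs from compound 2 by chloro in place of hydrogen on an aromatic carbon. Compound 3 also carries a halogen on the ring that bears the amino group, and it sits at the limit (the limit of < 10 nM in this assay, at which 1 of the 3 values shown sits). For compound 4 a step to stronger inhibition, well beyond the scatter, is expected, a 58-fold lower number from compound 2 to compound 4 (1.76 log units; beyond the scatter), giving an estimate of 15 nM (range 3 nM to 80 nM).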

Compound 4, concentration for 50% growth inhibition: 40 nM
Beside the measured number, compound 4's estimate is 2.7-fold (0.43 log units) below it; low and high end bracket the measured number.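

Chloro in place of hydrogen, ortho to an amino group, gives the first step in this series that changes a single place, and it is large: in this assay there is a 22-fold lower number from compound 2 to compound 4 (1.34 log units; beyond the scatter). This shows that one chlorine atom at this position is enough, on its own, to move the number well beyond the scatter.

Going by these compounds, whether bromo, methoxy or a nitrile at the same position would give a step of similar size remains open. Nothing shown explains why this one change has so large a step.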